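The source may hold more compounds than are shown below. What is called first, only, known or untested is meant among the compounds shown, and "the series" means these compounds.

Compound 1 `CCOC(=O)c1c(C)oc2ncnc(Nc3cccc(C)c3)c12` is examined in a functional assay on MCF7 cells (Homo sapiens) for cytotoxicity, read by MTT assay, with a stated time of 72 h; on this read-out lower numbers stand for stronger inhibition and higher numbers for weaker inhibition. In this assay compound 1 gives > 1000000 nM, which is a limit of the assay and not a number. Compound 2 `CCOC(=O)c1c(C)oc2ncnc(Nc3ccccc3)c12` gives 851000 nM in this assay. The change (hydrogen in place of methyl on an aromatic carbon), placed on an aromatic carbon of a six-membered aromatic ring of carbon only, meta to a large group, produces an at least 1.1-fold lower number from compound 1 to compound 2 (0.07 log units; that floor lies within the scatter). Compound 3 `CCOC(=O)c1c(C)oc2ncnc(Nc3ccc(OCc4ccc(C)cc4)cc3)c12` gives > 1000000 nM in this assay, again a limit. This amounts to an at least 1.1-fold higher number from compound 2 to compound 3 (0.07 log units; that floor lies within the scatter). The difference between the cores of compound 1 and compound 3 is not broken down here. Compound 4 `CCOC(=O)c1c(C)oc2ncnc(Nc3ccc(OCc4ccccc4)cc3)c12` differs from compound 3 by hydrogen in place of methyl on an aromatic carbon, the same kind of change, but here para to a large group. Compound 4 is expected to stay near the limit, a step of a number no higher from compound 3 to compound 4 (the limit leaves the size open), because an at least 1.1-fold lower number from compound 1 to compound 2 (0.07 log units; that floor lies within the scatter) already lies within the scatter. The estimate for compound 4 is 1000000 nM, between 400000 nM and 3000000 nM.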

Compound 4, half-maximal inhibitory concentration: > 1000000 nM
Compound 4 was reported as a limit; the forecaster's own chance of this, stated with the estimate: 70%; the middle value sits exactly at the limit.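

In this assay compound 4 gives > 1000000 nM, which is a limit and not a number. Hydrogen in place of methyl was readable only as a floor on the core of compound 1, and the results do not show whether that step carries over to compound 3 and compound 4, since the step between these two cannot be read: the limit of > 1000000 nM in this assay, at which 3 of the 4 values shown sit. Benzyloxy in place of hydrogen gives an at least 1.1-fold higher number from compound 2 to compound 4 (0.07 log units; that floor lies within the scatter), so the true size of this step stays open. The compounds shown leave open whether an amine or a carboxylic acid in place of the methyl of compound 3 would give a value that is a number rather than a limit in this assay.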